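Trichlorophenyl in Place of Bromophenyl at the Ether Oxygen

The source may hold more compounds than are shown below. What is called first, only, known or untested is meant among the compounds shown, and "the series" means these compounds.

Measured compounds:
compound 1 `NC1=NC2(CCSCC2)N(OCCCOc2ccc(Cl)c(Cl)c2)C(N)=N1` – 89.8%
compound 2 `CC(C)(C)c1ccc(OCCCON2C(N)=NC(N)=NC23CCSCC3)cc1` – 86.6%
compound 3 `NC1=NC2(CCSCC2)N(OCCCOc2ccc(Br)cc2)C(N)=N1` – "not determined" (no result reported)

All three share the same core, a spiro-linked ring system carrying two amino groups, joined through a short chain to an aryl ether. They were tested in an assay on isolated protein for inhibition of Dihydrofolate reductase (Homo sapiens), read by spectrophotometry, using NADPH, with stated times of 5 s and 6 min, tested at 50 uM (on this read-out higher numbers stand for a stronger effect at the one concentration tested and lower numbers for a weaker effect), where compound 1 gives 89.8% and compound 2 gives 86.6%. These two values lie within the scatter of each other, so no order between them can be read. Compound 3 has no single number: its result in this assay is given as "not determined" (no result reported), so it serves only as the structural starting point.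

Compound 4 `NC1=NC2(CCSCC2)N(OCCCOc2cc(Cl)c(Cl)cc2Cl)C(N)=N1` differs from compound 3 in one place: 2,4,5-trichlorophenyl in place of 4-bromophenyl on an oxygen on a saturated carbon. Since compound 3 carries no value, the expectation for compound 4 rests on compounds 1 and 2, both aryl ethers of the same core and both near the top of the range at the single concentration tested. The step from compound 3 to compound 4 is expected to be none beyond the scatter, with compound 4 falling alongside compounds 1 and 2.

Compound 4 is therefore expected to give about 88% in this assay, estimated between 72% and 97%.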

Compound 4, a percentage reported as inhibition, at one concentration (the size of the read-out at that concentration, not a potency): 94.4%
Compound 4: middle estimate off by 6.4 percentage points, on the low side; measured number inside the range.
By their numbers in this assay, from the lowest: compounds 2, 1 and 4 (each within the scatter of the next).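

In this assay, adding one more chloro in place of hydrogen on an aromatic carbon gives a number 4.6 percentage points higher from compound 1 to compound 4 (within the scatter), so this added chlorine leaves no readable mark on the result at the one concentration tested. The swap of 4-bromophenyl for 2,4,5-trichlorophenyl cannot be read as a step since compound 3 has no number, but what compound 4 does show is that the aryl group on the oxygen at the end of the saturated chain can carry three chlorines, 9 heavy atoms in all, and still give 94.4%. The data shown offer no independent measurement that could explain this result or tie it to any property of the chlorines.

On these data alone, whether this position would also hold up with a very different group on the aromatic ring, such as a carboxylic acid or an amine, or with a longer chain leading to the ring, remains open. A read-out at one concentration also leaves open how compound 1 and compound 4 would compare as measures of potency.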